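Benzimidazolylmethyl sulfanyl variant of the dinitrile core

A few compounds are considered here, and "the series" means these few. Any claim that something is new, unique, unknown or untested is made for them only; others in the source may bear on it.

The series shares a dinitrile core carrying a cyclopropylmethoxyphenyl group. In an assay on CHO cells for displacement of a labelled ligand from adenosine receptor A3 (Homo sapiens), read by scintillation counting, with a stated time of 120 min, tested at 1 uM (a higher number here means more inhibition at the concentration tested (going by the name of the read-out), a lower number less inhibition), compound 1 `N#Cc1c(N)nc2sc(C(N)=O)c(N)c2c1-c1ccc(OCC2CC2)cc1` gives 13%, and compound 2 `N#Cc1c(N)nc(SCC(=O)NCO)c(C#N)c1-c1ccc(OCC2CC2)cc1` gives 8%. The two values lie within the scatter of each other, so compound 2 stands at the same low level as compound 1; neither shows much displacement at the concentration tested.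

Compound 3 `N#Cc1c(N)nc(SCc2nc3ccccc3[nH]2)c(C#N)c1-c1ccc(OCC2CC2)cc1` differs from compound 2 only by the change (1H-benzimidazol-2-yl in place of (hydroxymethyl)carbamoyl on a saturated chain carbon bound to a sulfur). For the measured compounds named here, no measured pair in the set shows what such a change does in this assay, so the expectation rests on the low level of both measured compounds alone. The step from compound 2 to compound 3 is expected to be a number 7 percentage points higher from compound 2 to compound 3 (within the scatter), that is no change beyond the scatter, since nothing in the data points either way. Compound 3 is estimated at 15%, with a range from 0% to 40%.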

Compound 3, a percentage reported as inhibition, at one concentration (the size of the read-out at that concentration, not a potency): 1%
The estimate for compound 3 lay 14 percentage points above the measured number; low and high end bracket the measured number.
By their numbers in this assay, from the lowest: compounds 3, 2 and 1 (each within the scatter of the next, the first and the last beyond it).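

At the saturated chain carbon bound to a sulfur, 1H-benzimidazol-2-yl in place of (hydroxymethyl)carbamoyl gives, in this assay, a number 7 percentage points lower from compound 2 to compound 3 (within the scatter) for this change. For the compounds shown here, this is the first step read at this position, and it shows that exchanging a group with no ring for one with a five-membered and a six-membered aromatic ring leaves the read-out at the same low level. Nothing measured here explains this result.

On these data alone, whether a carboxylic acid or an amine on this chain carbon, or a longer chain between the sulfur and the 1H-benzimidazol-2-yl, would give more inhibition stays open. With readings at a single concentration, any potency differences among these compounds also remain unresolved.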